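Half-life in rat small intestine for two amidine esters

A few compounds are considered here, and "the series" means these few. Any claim that something is new, unique, unknown or untested is made for them only; others in the source may bear on it.

Compound 1 `CCOC(=O)CCCN(C(=O)/C(C)=C/c1ccc(C(=O)Oc2ccc(C(=N)N)cc2)cc1)C(C(=O)OCC)C(=O)OCC`: 1 h
Compound 2 `C/C(=C\c1ccc(C(=O)Oc2ccc(C(=N)N)cc2)cc1)C(=O)N(CC(=O)O)C1CCCCC1`: 0.817 h

Of the compounds shown here, two have been measured in an in vitro ADME assay on the whole organism (small intestine) for pharmacokinetics, with Rattus norvegicus as the target; a higher number here means that the compound lasts longer, a lower number that the compound disappears faster. Compound 1 gives 1 h, and compound 2 gives 0.817 h. Compound 2 has the lower of the two numbers, but its nearest neighbour, compound 1, sits only a small distance away, and that gap is within the scatter, so the two cannot be ordered.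

Compound 3 `C=CCN(CCC(=O)OCC)C(=O)/C(C)=C/c1ccc(C(=O)Oc2ccc(C(=N)N)cc2)cc1` differs from compound 2 in one place: allyl(2-(ethoxycarbonyl)ethyl)amino in place of (carboxymethyl)(cyclohexyl)amino on a carbonyl carbon. The two share every other atom and the same core. Among the measured compounds shown here, since no step between measured compounds has been worked out, the change offers no directly comparable precedent; the only guide is that compound 1, which also carries ethyl ester groups, and compound 2, which carries a free acid, sit within the scatter of each other in this assay.

On that basis the step of a 1.1-fold higher number from compound 2 to compound 3 (0.04 log units; within the scatter) is expected to be small, in neither direction beyond the scatter. Compound 3 is therefore estimated at 0.9 h, with a plausible range from 0.4 h to 2 h.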

Compound 3, half-life: 1 h
Compound 3: middle estimate off by 1.1-fold (0.05 log units), on the low side; measured number inside the range.
By their numbers in this assay, from the lowest: compounds 2, 1 and 3 (each within the scatter of the next).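

In this assay, among the compounds shown here, the exchange of (carboxymethyl)(cyclohexyl)amino for allyl(2-(ethoxycarbonyl)ethyl)amino on a carbonyl carbon gives a 1.2-fold higher number from compound 2 to compound 3 (0.09 log units; within the scatter) and is the first single-place step available for this position. The entering group has no ring and no hydrogen-bond donor, yet the two compounds remain within the scatter of each other, so this exchange does not separate them in this read-out. Nothing measured here bears on the result.

The exchange alters the ring, the acid and the ester together, so it cannot show what any one of these contributes alone. From the compounds shown here alone, whether a benzyl or dimethylamino group on the same carbonyl carbon would give a number beyond the scatter remains open.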